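The source may hold more compounds than are shown below. What is called first, only, known or untested is meant among the compounds shown, and "the series" means these compounds.

In an assay on CHO cells for displacement of a labelled ligand from adenosine receptor A3 (Homo sapiens), read by scintillation counting, tested at 10 uM (on this read-out lower numbers stand for less inhibition and higher numbers for more inhibition at the one concentration tested (going by the name of the read-out)), compound 1 `CC(C)(C)Cc1csc(N)c1C(=O)c1ccc(Cl)cc1` gives 5%, compound 2 `CC(C)(C)Cc1c(-c2ccc(F)cc2)sc(N)c1C(=O)c1ccc(Cl)cc1` gives 9%, and compound 3 `CC(C)(C)Cc1c(-c2ccc(Cl)c(Cl)c2)sc(N)c1C(=O)c1ccc(Cl)cc1` gives 1%. Compound 3 carries the lowest of the three numbers, yet its gaps to the others fall within the scatter: a number 4 percentage points lower from compound 1 to compound 3 (within the scatter) and a number 8 percentage points lower from compound 2 to compound 3 (within the scatter), so the three cannot be told apart. Compound 4 `Cc1cccc(-c2sc(N)c(C(=O)c3ccc(Cl)cc3)c2CC(C)(C)C)c1` differs from compound 3 in one place: 3-methylphenyl in place of 3,4-dichlorophenyl on an aromatic carbon. Within the data shown here, two measured steps bear on this change, both exchanging the group on that same aromatic carbon: a number 4 percentage points higher from compound 1 to compound 2 (within the scatter) and a number 8 percentage points lower from compound 2 to compound 3 (within the scatter). Neither shifted this assay beyond the scatter, so the expected step is again none beyond the scatter, a number 3 percentage points higher from compound 3 to compound 4 (within the scatter). Compound 4 is therefore estimated at 4%, within a range from -6% to 14%.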

Compound 4, a percentage reported as inhibition, at one concentration (the size of the read-out at that concentration, not a potency): 1%
Beside the measured number, compound 4's estimate is 3 percentage points above it; measured number inside the range.
By their numbers in this assay, from the lowest: compounds 3, 4, 1 and 2 (each within the scatter of the next).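

At this aromatic carbon a further aryl group, 3-methylphenyl, still leaves this assay inside the scatter (no change at the digits printed from compound 3 to compound 4 (within the scatter)). The same holds against the other two compounds (a number 8 percentage points lower from compound 2 to compound 4 (within the scatter); a number 4 percentage points lower from compound 1 to compound 4 (within the scatter)). So hydrogen and all three aryl groups shown read alike here, and no information at hand accounts for this. Going by these compounds, what stays open is whether any group on this carbon can move the number beyond the scatter, for example an aminomethyl group or a carboxylic acid.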